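Compound 4: nitro in place of cyano

This account rests on a few compounds, and the source may have more. Where it says the series, first, only, none or still open, it means among the compounds named here.

In a functional assay on B16-F10 cells (Mus musculus) for inhibition, read by MTT assay, with a stated time of 72 h (on this read-out higher numbers stand for weaker inhibition and lower numbers for stronger inhibition), compound 3 (`CC1(C)CC(NC(=S)Nc2ccc(C#N)cc2)c2cc(Cl)ccc2O1`) gives 7000 nM and stands level with compound 1 (`CC1(C)CC(NC(=S)Nc2cccc(C#N)c2)c2cc(Br)ccc2O1`) at 7000 nM while compound 2 (`CC1(C)CC(NC(=S)Nc2ccc(C#N)cc2)c2cc(F)ccc2O1`) gives 5000 nM within the scatter of both. Compound 4 (`CC1(C)CC(NC(=S)Nc2ccc([N+](=O)[O-])cc2)c2cc(Cl)ccc2O1`) carries nitro in place of cyano on an aromatic carbon, para to a large group (nitro in place of cyano on an aromatic carbon). Among the compounds with values here, the one measured step (a 1.4-fold higher number from compound 2 to compound 3 (0.15 log units; within the scatter)) is chloro in place of fluoro, lies within the scatter and leaves the cyano untouched. Within the data shown here, no measured step covers this exchange, so the expectation starts from compound 3 (7000 nM) with no shift beyond the scatter in this assay and an expected step (a 1.2-fold lower number from compound 3 to compound 4 (0.07 log units; within the scatter)) of that small size. Compound 4 is estimated at 6000 nM with an expected range from 2500 nM to 15000 nM on repeat measurement.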

Compound 4, half-maximal inhibitory concentration: 3000 nM
For compound 4 the middle estimate is 2.0-fold (0.30 log units) above the measured one; the range from low to high includes it.
By their numbers in this assay, from the lowest: compounds 4, 2, 1 and 3 (each within the scatter of the next, the first and the last beyond it).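

Nitro in place of cyano on an aromatic carbon, para to a large group, gives in this assay a step of a 2.3-fold lower number from compound 3 to compound 4 (0.37 log units; beyond the scatter) and so moves the number beyond the scatter. Within the data shown here, the other exchange, chloro in place of fluoro, gives a 1.4-fold higher number from compound 2 to compound 3 (0.15 log units; within the scatter) and stays within it, so this is the first sign that the group at this carbon matters. No measurement at hand explains the step.

Going by these compounds, whether an amine or a carboxylic acid at this carbon would give a lower number stays open. Also open, on these data alone, is whether the same step holds with fluoro in place of chloro.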